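Aryl swap on the piperazine amide: compound 1 to compound 4

The compounds below may be only part of what the source reports. "The series", "measured", "known", "first", "only" and "open" are said of these compounds alone.

Measured in a functional assay on the whole organism (strain CD1) with Mus musculus as the target, with a stated time of 0.5 h; a higher number here means that more compound is needed for the effect, a lower number that less compound is needed:
- compound 1 `CCC1(C)CC(=O)N(CC(=O)N2CCN(c3ccc(Cl)cc3)CC2)C1=O` gives 100 mg/kg
- compound 2 `Cc1cccc(N2CCN(C(=O)CN3C(=O)CC(C)C3=O)CC2)c1` gives 100 mg/kg
- compound 3 `CC1CC(=O)N(CC(=O)N2CCN(c3ccc(Cl)c(Cl)c3)CC2)C1=O` gives 100 mg/kg

Compound 1 stands level with compound 2 and compound 3 at the digits shown; its nearest neighbour is compound 2 and its furthest compound 3, and in both cases the difference lies within the scatter. Among the measured compounds shown here, the one measured step between neighbours, no change at the digits printed from compound 2 to compound 3 (within the scatter), changes the aryl group on the ring nitrogen and leaves the minimum effective dose unchanged.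

Compound 4 `CCC1(C)CC(=O)N(CC(=O)N2CCN(c3ccccc3C)CC2)C1=O` differs from compound 1 in the same place: 2-methylphenyl in place of 4-chlorophenyl on an amine nitrogen in a ring. The step that bears on this is no change at the digits printed from compound 2 to compound 3 (within the scatter), since it also exchanges one aryl group for another on that ring nitrogen with no change beyond the scatter. Because no change at the digits printed from compound 2 to compound 3 (within the scatter) showed nothing, no step beyond the scatter is expected here either. The step expected in this assay is no change at the digits printed from compound 1 to compound 4 (within the scatter). For compound 4 the expected value is 100 mg/kg, with a range from 50 mg/kg to 200 mg/kg.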

Compound 4, minimum effective dose: 100 mg/kg
The estimate for compound 4 equals the measured number at the digits printed; the range from low to high includes it.
By their numbers in this assay, from the lowest: compounds 1, 2, 3 and 4 (each within the scatter of the next).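

In this assay, the exchange of 4-chlorophenyl for 2-methylphenyl on the amine nitrogen in the ring gives no change at the digits printed from compound 1 to compound 4 (within the scatter). This carries the flat result of the earlier aryl exchange over to the core of compound 1, and on this core the chlorine on the aryl group is not needed to hold the minimum effective dose at the value of compound 1. No supporting data bear on why the dose holds across this exchange.

The compounds shown leave open whether any group at this position can shift the minimum effective dose, as all four share one value. A benzyl group or a pyridyl ring on that nitrogen, or a carboxylic acid on the phenyl ring, would test this.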